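Methoxy to ethoxy, the same step read across two cores

This account rests on a few compounds, and the source may have more. Where it says the series, first, only, none or still open, it means among the compounds named here.

Compound 1 `COc1cccc(-c2ncc(C(=O)O)c(=O)[nH]2)c1`: 10 mg/kg
Compound 2 `CCOc1cccc(-c2ncc(C(=O)O)c(=O)[nH]2)c1`: 5 mg/kg
Compound 3 `CCOC(=O)c1cnc(-c2ccccc2OC)[nH]c1=O`: 10 mg/kg

Going by the values given here, in a functional assay on the whole organism (strain Sprague-Dawley) for inhibition, with Rattus norvegicus as the target, with a stated time of 10 min (on this read-out lower numbers stand for an effect already at smaller amounts and higher numbers for an effect only at larger amounts of compound), the only single-point change measured so far is methyl in place of hydrogen on a saturated chain carbon bound to an oxygen on an aromatic ring, which gave a 2.0-fold lower number from compound 1 to compound 2 (0.30 log units; within the scatter). Compound 3 stands level with compound 1 in this assay; the difference between the two cores is not broken down here. Compound 4 `CCOC(=O)c1cnc(-c2ccccc2OCC)[nH]c1=O` carries the same change on the core of compound 3, namely (methyl in place of hydrogen on a saturated chain carbon bound to an oxygen on an aromatic ring), at a place described in the same words as for the pair of compound 1 and compound 2. The expected step, resting on a 2.0-fold lower number from compound 1 to compound 2 (0.30 log units; within the scatter), is a 1.7-fold lower number from compound 3 to compound 4 (0.22 log units; within the scatter), which would leave compound 4 within the scatter of compound 3. Compound 4 is therefore estimated at 6 mg/kg in this assay, with a range from 3 mg/kg to 12 mg/kg.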

Compound 4, dose for 50% inhibition: 2 mg/kg
Estimate against measurement, compound 4: 3.0-fold (0.48 log units) above, outside the stated range (below it).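

In this assay, methoxy to ethoxy on the second core gave a 5.0-fold lower number from compound 3 to compound 4 (0.70 log units; beyond the scatter). Going by these compounds alone, only this step lies beyond the scatter, yet the two steps cannot be told apart from each other: the same change on two cores in this assay, a 2.0-fold lower number (0.30 log units; within the scatter) from compound 1 to compound 2 and a 5.0-fold lower number (0.70 log units; beyond the scatter) from compound 3 to compound 4, 2.5-fold (0.40 log units) apart, within the scatter of two such steps. The change can therefore be carried between these two cores with no measurable difference in its size, but two pairs establish no rule for other cores and do not show that either core responds more strongly.

The compounds shown leave open whether a longer chain, such as propoxy, would extend the step on either core. They also leave open what an amine in place of the ethoxy group would give.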